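A few compounds are considered here, and "the series" means these few. Any claim that something is new, unique, unknown or untested is made for them only; others in the source may bear on it.

Three compounds share one core and differ only in the groups carried on the outer six-membered aromatic ring of carbon only. Compound 1 `CCOc1ccc(/C=N/n2c(S)nnc2-c2cnccn2)cc1OC` gives 58800 nM in a functional assay, with a stated time of 30 min; on this read-out higher numbers stand for weaker inhibition and lower numbers for stronger inhibition. Compound 2 `Oc1ccc(/C=N/n2c(S)nnc2-c2cnccn2)c(O)c1` gives 75900 nM in this assay. Compound 3 `Fc1ccc(/C=N/n2c(S)nnc2-c2cnccn2)cc1` gives 58800 nM in this assay. On these numbers compound 3 stands level with compound 1 at the digits shown and, together with compound 1, at the lowest of the three values; compound 2 lies a little higher, but that gap is within the scatter, so none of the three can be ranked against the others.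

Compound 4 `Sc1nnc(-c2cnccn2)n1/N=C/c1ccc(Cl)cc1` has not yet been measured in this assay. It differs from compound 3 in one place: chloro in place of fluoro on an aromatic carbon, which read one bond further out is 4-fluorophenyl becoming 4-chlorophenyl. Among the measured compounds shown here, no pair of measured compounds covers this exchange, so nothing beyond the three values themselves, all sitting close together, bears on it. The change is a small one, and the step is expected to be a 1.3-fold lower number from compound 3 to compound 4 (0.12 log units; within the scatter), no larger than the scatter, if anything a slight move toward the lower numbers. Compound 4 is therefore estimated at 45000 nM in this assay, with a range from 20000 nM to 110000 nM.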

Compound 4, half-maximal inhibitory concentration: 39800 nM
Estimate against measurement, compound 4: 1.1-fold (0.05 log units) above; low and high end bracket the measured number.
By their numbers in this assay, from the lowest: compounds 4, 1, 3 and 2 (each within the scatter of the next).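

Chloro in place of fluoro on this aromatic carbon, para to a large group, gives the first reading of a single change among these compounds in this assay: a 1.5-fold lower number from compound 3 to compound 4 (0.17 log units; within the scatter). At this position, then, the exchange of fluoro for chloro, or 4-fluorophenyl for 4-chlorophenyl, makes no difference that can be told from the scatter, and the two compounds cannot be ranked against each other. Nothing measured alongside these compounds bears on why this step is as small as it is.

Compounds 1 and 2 each differ from compound 3 and compound 4 in more than one place, so no steps can be read from them, and the role of their ring groups stays unresolved despite the closeness of all four values. Going by these compounds, whether an amine, a carboxylic acid or a longer alkoxy chain on this same carbon would move the number beyond the scatter remains open, as does whether any change to the shared core would do so.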